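Methylsulfanyl in place of bromo on compound 2

The compounds below may be only part of what the source reports. "The series", "measured", "known", "first", "only" and "open" are said of these compounds alone.

Among the measured compounds shown here, in a functional assay on SK-OV-3 cells (Homo sapiens) for cytotoxicity (a lower number here means a stronger inhibitor of growth, a higher number a weaker inhibitor of growth), compound 1 (`CSc1ccc(C2=C(c3ccc(F)c(C)c3)C(=O)N3CCCC3C2)cc1`) gives 300 nM and compound 2 (`CSc1ccc(C2=C(c3ccc(Br)cc3)C(=O)N3CCCC3C2)cc1`) gives 9000 nM as the higher of the two numbers so far. Compound 3 (`CSc1ccc(C2=C(c3ccc(SC)cc3)C(=O)N3CCCC3C2)cc1`) is still unmeasured and carries methylsulfanyl in place of bromo on an aromatic carbon para to a large group. For the measured compounds named here, only one measured step bears on this, a 30-fold higher number from compound 1 to compound 2 (1.48 log units; beyond the scatter) with 4-bromophenyl in place of 4-fluoro-3-methylphenyl, and it is large. Going by the values given here, no measured compound has methylsulfanyl on this ring in place of bromo, so that step indicates only the scale of change possible here. Compound 2 sits at the high end, so a moderate move toward a lower number is expected. The expected step is a 2.3-fold lower number from compound 2 to compound 3 (0.35 log units; beyond the scatter) and it stays smaller than the measured one. For compound 3 the estimate is 4000 nM with 1000 nM to 15000 nM as the expected range.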

Compound 3, concentration for 50% growth inhibition: 2000 nM
Compound 3: middle estimate off by 2.0-fold (0.30 log units), on the high side, within the range that was stated.
By their numbers in this assay, from the lowest: compound 1; then compound 3; then compound 2.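

In this assay, the change from bromo to methylsulfanyl on this aromatic carbon, with the rest of the structure held fixed, gives a 4.5-fold lower number from compound 2 to compound 3 (0.65 log units; beyond the scatter), so a swap at this one position moves the number beyond the scatter. The 4-(methylsulfanyl)phenyl group still falls short of the 4-fluoro-3-methylphenyl group, as the comparison on the double-bonded ring carbon gives a 6.7-fold higher number from compound 1 to compound 3 (0.82 log units; beyond the scatter), and methylsulfanyl therefore closes only part of the gap left by the 4-bromophenyl group. The evidence at hand offers no explanation for either step.

Going by these compounds, whether a longer chain on the sulfur, a methoxy group or an amine at this aromatic carbon would lower the number further remains open. Also open, on these data alone, is whether this step would hold with the 4-fluoro-3-methylphenyl group kept on the double-bonded ring carbon.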